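This account rests on a few compounds, and the source may have more. Where it says the series, first, only, none or still open, it means among the compounds named here.

Among the measured compounds shown here, the two compounds measured so far share one core. Compound 1 `c1cncc(N2C[C@H]3CCNC[C@H]32)c1` gives, in a functional assay on HEK293 cells for agonist activity at Neuronal acetylcholine receptor; alpha3/beta4 (Homo sapiens), read by FLIPR (a lower number here means that less compound is needed, a higher number that more compound is needed for the effect), 1540 nM. Compound 2 `N#Cc1cncc(N2C[C@H]3CCNC[C@H]32)c1` gives in this assay 5560 nM; this is the highest of the two numbers, with compound 1 as its nearest neighbour, and the step between them is beyond the usual scatter. For the measured compounds named here, the one measured step, a 3.6-fold higher number from compound 1 to compound 2 (0.56 log units; beyond the scatter), describes how the two differ. Compound 3 `N#Cc1cc(N2C[C@H]3CCNC[C@H]32)cnc1Br` is not yet measured. It differs from compound 2 in one place: bromo in place of hydrogen on an aromatic carbon. Going by the values given here, no measured step involves a bromo group, so the only step available is a 3.6-fold higher number from compound 1 to compound 2 (0.56 log units; beyond the scatter), which concerns a different change and bears on compound 3 only loosely. A further small change on compound 2 is therefore expected to move the number in this assay only a little, perhaps a 1.3-fold higher number from compound 2 to compound 3 (0.10 log units; within the scatter). Compound 3 is estimated at 7000 nM, within a range from 2500 nM to 20000 nM.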

Compound 3, half-maximal effective concentration: 238 nM
Estimate against measurement, compound 3: 29-fold (1.47 log units) above; the whole stated range lies above it.
By their numbers in this assay, from the lowest: compound 3; then compound 1; then compound 2.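

In this assay, the aromatic carbon next to the ring nitrogen and ortho to a cyano group proves highly sensitive to substitution, as a single bromine atom in place of hydrogen produces a large step (a 23-fold lower number from compound 2 to compound 3 (1.37 log units; beyond the scatter)). This step runs in the opposite direction to the only earlier one (a 3.6-fold higher number from compound 1 to compound 2 (0.56 log units; beyond the scatter)) and is larger, so a small change on this ring can shift the number either way. Nothing available explains why bromo has this effect.

Going by these compounds, it remains open whether the lower number is specific to bromo or would also appear with chloro, methyl or an amine at this carbon. It is also unknown whether bromo would have the same effect on compound 1, which lacks the cyano group.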